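Swapping acetamido for fluoro on the pendant aryl ring

A few compounds are considered here, and "the series" means these few. Any claim that something is new, unique, unknown or untested is made for them only; others in the source may bear on it.

Three analogues sharing the core of compound 1 `CCOC(=O)c1c(-c2cccc(C)c2)csc1N` have been tested in an assay on isolated protein for inhibition of protein kinase C zeta type (Homo sapiens), with stated times of 1 h and 2.5 min, tested at 30 uM; on this read-out higher numbers stand for more inhibition at the one concentration tested (going by the name of the read-out) and lower numbers for less inhibition. Compound 1 gives 77%. Compound 2 `CCOC(=O)c1c(-c2cccc(NC(C)=O)c2)csc1N` gives 89%, the highest of the three numbers; its nearest neighbour is compound 1 and its furthest is compound 3 `CCOC(=O)c1c(-c2ccc(C(F)(F)F)cc2)csc1N`, which carries a trifluoromethyl group and gives 16%, far below compound 2. Within the data shown here, the single one-site step among the measured compounds is a number 12 percentage points higher from compound 1 to compound 2 (beyond the scatter), showing that acetamido adds a modest amount over methyl at the same place on the ring.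

Among the measured compounds shown here, compound 4 `CCOC(=O)c1c(-c2cccc(F)c2)csc1N` has not yet been measured. fluoro in place of acetamido on an aromatic carbon The only measured step that bears on this change is the one from compound 1 to compound 2, and the present change runs the other way: the acetamido that lifted the number there is removed. Fluoro, like methyl, brings no hydrogen-bond donor or acceptor, so a loss of roughly the size seen between compound 1 and compound 2, perhaps somewhat larger, is expected, giving a number 19 percentage points lower from compound 2 to compound 4 (beyond the scatter). Compound 4 is therefore estimated at 70%, within a range from 45% to 88%.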

Compound 4, a percentage reported as inhibition, at one concentration (the size of the read-out at that concentration, not a potency): 38%
Compound 4: middle estimate off by 32 percentage points, on the high side; measured number below the stated range.
By their numbers in this assay, from the lowest: compound 3; then compound 4; then compound 1; then compound 2.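

In this assay, the group at this place on the pendant aryl ring matters far more than the earlier modest step suggested: replacing acetamido with fluoro gives a large fall (a number 51 percentage points lower from compound 2 to compound 4 (beyond the scatter)), and replacing methyl with fluoro also gives a large fall (a number 39 percentage points lower from compound 1 to compound 4 (beyond the scatter)). Removing acetamido therefore does not by itself account for the whole loss, since compound 1 also lacks that group and still gives 77%, so the three groups now fall in the order fluoro, methyl, acetamido, with methyl much closer to acetamido than to fluoro. Nothing available explains why fluoro falls so far below methyl at this place.

As far as these compounds go, whether an amine, a methoxy group or a longer amide chain at the same place would stand with acetamido, with methyl or with fluoro remains open, and with it what separates the high numbers from the low one. The compounds shown also leave open whether fluoro would give a similar fall elsewhere on the ring or on a different ester of the shared core.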